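The source may report more compounds than this note shows. Statements on the series, on what has been measured and on what is new or still open speak of the compounds shown alone.

Compound 1 `Cc1ccc(-c2cccc(OC(=O)NC3CCCCC3)c2)cc1`: 155 nM; compound 2 `NC(=O)c1ccc(-c2cccc(OC(=O)NC3CCCCC3)c2)cc1`: 5910 nM.

In an assay on cell membranes for binding affinity to Fatty-acid amide hydrolase 1 (Rattus norvegicus) (on this read-out lower numbers stand for stronger inhibition and higher numbers for weaker inhibition), compound 2 gives the highest of the two numbers, its nearest neighbour being compound 1. Among the compounds with values here, the only step that bears on compound 3 `O=C(NC1CCCCC1)Oc1cccc(-c2ccc(F)cc2)c1` is a 38-fold higher number from compound 1 to compound 2 (1.58 log units; beyond the scatter), a large rise when the carbamoyl entered. Compound 3 differs from compound 2 by fluoro in place of carbamoyl on an aromatic carbon. Since the carbamoyl, which carried that rise, leaves again and a group with no donors or acceptors enters, a large fall in this assay is expected, about a 24-fold lower number from compound 2 to compound 3 (1.37 log units; beyond the scatter). Compound 3 is therefore estimated at 250 nM, within 80 nM to 800 nM.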

Compound 3, half-maximal inhibitory concentration: 65 nM
Compound 3: the middle estimate sits 3.8-fold (0.59 log units) above what was measured; the whole stated range lies above it.
By their numbers in this assay, from the lowest: compound 3; then compound 1; then compound 2.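

In this assay the position para to a large group tolerates the loss of the carbamoyl's hydrogen-bond donor and acceptor, with fluoro giving a 91-fold lower number from compound 2 to compound 3 (1.96 log units; beyond the scatter) and more than reversing the earlier rise. Small groups also separate here, since fluoro in place of methyl gives a 2.4-fold lower number from compound 1 to compound 3 (0.38 log units; beyond the scatter) and this modest step lies beyond the scatter. The two groups with no hydrogen-bond donors or acceptors both sit well below the carbamoyl compound.

From the compounds shown here alone, how chloro, methoxy, a nitrile or a carboxylic acid would behave at this position remains open. No measurement shown gives a reason for these differences.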